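Pyridin-4-yl in place of 3-(methoxycarbonyl)phenyl

The source may report more compounds than this note shows. Statements on the series, on what has been measured and on what is new or still open speak of the compounds shown alone.

In an ADME assay on S9 fraction from liver (Rattus norvegicus) for metabolic stability, read by LC-MS, using NADPH, with a stated time of 30 min (on this read-out higher numbers stand for a more stable compound and lower numbers for a less stable compound), compound 1 `CCCCCCCCc1ccc(OCC(=O)Cn2ncnn2)cc1` gives < 5%, which is a limit and not a number. For the measured compounds named here, compound 2 `CCCCCCCCc1ccc(OCC(=O)Cn2nnc(-c3cccc(C(=O)OC)c3)n2)cc1` gives 19%, the only actual number so far. Going by the values given here, the one measured step, a number at least 14 percentage points higher from compound 1 to compound 2 (beyond the scatter), put 3-(methoxycarbonyl)phenyl in place of hydrogen and starts from the limit of < 5% in this assay, at which 1 of the 2 values shown sits. Compound 3 `CCCCCCCCc1ccc(OCC(=O)Cn2nnc(-c3ccncc3)n2)cc1` carries pyridin-4-yl in place of 3-(methoxycarbonyl)phenyl on an aromatic carbon. With a six-membered aromatic ring kept at that carbon, the expected a number 4 percentage points lower from compound 2 to compound 3 (within the scatter) stays within the scatter, its direction open. For compound 3 the estimate in this assay is 15%, ranging from 5% to 35%.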

Compound 3, percent of the compound remaining: < 5%
Compound 3 gave a limit, no number; the forecaster's own chance of this, stated with the estimate: 20%; at least 10 percentage points between middle value and limit.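

At this aromatic carbon of the five-membered aromatic ring with 4 nitrogen, keeping a six-membered aromatic ring is not enough to hold the read-out in this assay: pyridin-4-yl in place of 3-(methoxycarbonyl)phenyl gives a number at least 14 percentage points lower from compound 2 to compound 3 (beyond the scatter). The value of compound 3 is a limit and not a number, and the step from compound 1 to compound 3 cannot be read: the limit of < 5% in this assay, at which 2 of the 3 values shown sit.

The compounds shown leave open whether the methoxycarbonyl group or the carbon-only ring separates compound 2 from compound 3. Unsubstituted phenyl, or a carboxylic acid in place of the methyl ester, would divide these two readings.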